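This account rests on a few compounds, and the source may have more. Where it says the series, first, only, none or still open, it means among the compounds named here.

Three compounds have so far been measured in an ADME assay on liver for metabolic stability, with Liver microsome (Homo sapiens) as the target, read by LC-MS, using microsomes, with a stated time of 5 h; a lower number here means slower removal, a higher number faster removal of the compound:

Compound 1 `O[C@H](c1ccccn1)[C@]1(c2ccc(C(F)(F)F)cc2)C[C@@H](O)C1`: 33.3 mL/min/kg
Compound 2 `C[C@]1(O)C[C@@](c2cccc(C(F)(F)F)c2)([C@H](O)c2ccccn2)C1`: 150 mL/min/kg
Compound 3 `C[C@]1(O)C[C@@](c2ccc(C(F)(F)F)cc2)([C@H](O)c2ccccn2)C1`: 50 mL/min/kg

Compound 2 gives the highest number of the three; its gaps to compound 3 and to compound 1 are both beyond the scatter. How the core of compound 2 differs from that of compound 3 is not broken down here. Compound 4 `O[C@H](c1ccccn1)[C@]1(c2cccc(C(F)(F)F)c2)C[C@@H](O)C1` has not been measured. It differs from compound 2 by hydrogen in place of methyl on a saturated ring carbon. The same change occurs between compound 3 and compound 1, where it gave a 1.5-fold lower number from compound 3 to compound 1 (0.18 log units; within the scatter). Because that step is a 1.5-fold lower number from compound 3 to compound 1 (0.18 log units; within the scatter), a step of similar size, a 1.5-fold lower number from compound 2 to compound 4 (0.18 log units; within the scatter), is expected from compound 2 in this assay. Compound 4 is therefore estimated at 100 mL/min/kg, most likely between 55 mL/min/kg and 180 mL/min/kg.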

Compound 4, clearance: 50 mL/min/kg
Beside the measured number, compound 4's estimate is 2.0-fold (0.30 log units) above it; measured number outside the range, below it.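

In this assay, hydrogen in place of methyl on a saturated ring carbon gives a 3.0-fold lower number from compound 2 to compound 4 (0.48 log units; beyond the scatter). Set beside the same change on the other core, the two steps do not differ beyond the scatter: the same change on two cores in this assay, a 1.5-fold lower number (0.18 log units; within the scatter) from compound 3 to compound 1 and a 3.0-fold lower number (0.48 log units; beyond the scatter) from compound 2 to compound 4, 2.0-fold (0.30 log units) apart, within the scatter of two such steps. Within the data shown here, as far as these two pairs can tell, the change carries over from one core to the other, but they show this for only two cores, only one of the two steps is itself beyond the scatter, and they fix no single size for the step.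

The compounds shown leave open what an ethyl group, a methoxy group or an amine would do on that ring carbon. Also open, as far as these compounds go, is whether the step holds with a nitrile in place of the trifluoromethyl.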